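The source may hold more compounds than are shown below. What is called first, only, known or untested is meant among the compounds shown, and "the series" means these compounds.

Compound 1 `O=C(/C=C/c1ccc([N+](=O)[O-])cc1)Nc1cc2c(Nc3ccc(F)c(Cl)c3)ncnc2cc1O[C@H]1CCOC1` carries a 4-nitrophenyl on the chain of its amide; in a functional assay on MCF7 cells (Homo sapiens) for cytotoxicity, read by MTT assay, with a stated time of 72 h (on this read-out lower numbers stand for stronger inhibition and higher numbers for weaker inhibition), compound 1 gives 26700 nM, the lower of the two numbers here, with compound 3 `COc1ccc(/C=C/C(=O)Nc2cc3c(Nc4ccc(F)c(Cl)c4)ncnc3cc2O[C@H]2CCOC2)c(OC)c1` close by at 28600 nM. Within the data shown here, the only comparable step, a 1.1-fold higher number from compound 1 to compound 3 (0.03 log units; within the scatter), shows that swapping the aryl on the chain hardly moves this assay. Compound 2 `COc1cc2ncnc(Nc3ccc(F)c(Cl)c3)c2cc1NC(=O)/C=C/c1ccc(F)cc1Cl`, which bears the same 2-chloro-4-fluorophenyl but a methoxy on the core, gives "not active" (no number reported) in this assay, no number being reported. Compound 4 `O=C(/C=C/c1ccc(F)cc1Cl)Nc1cc2c(Nc3ccc(F)c(Cl)c3)ncnc2cc1O[C@H]1CCOC1` differs from compound 1 by 2-chloro-4-fluorophenyl in place of 4-nitrophenyl on a double-bonded chain carbon bound to a double-bonded chain carbon. Given the flat step to compound 3 and the null result for compound 2, compound 4 is expected to give 38000 nM, within 12000 nM to 120000 nM, a step of a 1.4-fold higher number from compound 1 to compound 4 (0.15 log units; within the scatter) from compound 1.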

Compound 4, half-maximal inhibitory concentration: 26200 nM
For compound 4 the middle estimate is 1.5-fold (0.16 log units) above the measured one; measured number inside the range.
By their numbers in this assay, from the lowest: compounds 4, 1 and 3 (each within the scatter of the next).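

In this assay, 2-chloro-4-fluorophenyl at this place on the chain does not separate from either earlier aryl group (a 1.0-fold lower number from compound 1 to compound 4 (0.01 log units; within the scatter); a 1.1-fold lower number from compound 3 to compound 4 (0.04 log units; within the scatter)). Across compounds 1, 3 and 4, the 4-nitrophenyl, 2,4-dimethoxyphenyl and 2-chloro-4-fluorophenyl groups therefore all read alike. No measurement on hand explains this flatness.

On these data alone, whether an amine, a carboxylic acid or a longer chain in place of this aryl would move the number remains open. Compound 2, carrying the same 2-chloro-4-fluorophenyl, gives ("not active" (no number reported)), so its step to compound 4 cannot be read.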